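This account rests on a few compounds, and the source may have more. Where it says the series, first, only, none or still open, it means among the compounds named here.

Measured compounds:
compound 1, `CCCCOc1ccc(-c2nc3ncccn3c2NCc2nc[nH]c2C)cc1`: 100000 nM
compound 2, `CCCCOc1ccc(-c2nc3ncccn3c2N2C(=O)c3cccc(O)c3C2=O)cc1`: > 100000 nM
compound 3, `O=C(O)CCCOc1ccc(-c2nc3ncccn3c2NC2CCCCC2)cc1`: > 100000 nM

All three were run in a toxicity assay on A549 cells (Homo sapiens) for cytotoxicity, read by luminescence and CellTiter-Glo, with a stated time of 48 h; a lower number here means that less compound is tolerated, a higher number that more compound is tolerated. Compound 3 gives only a limit there, > 100000 nM, not a number. Compound 2 likewise returns a limit, > 100000 nM. Compound 1 gives a number, 100000 nM, at the same concentration. Compound 3 therefore stands at the limit of > 100000 nM in this assay, at which 2 of the 3 values shown sit, and nothing in this set separates any two compounds beyond the scatter.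

Compound 4, `Clc1ccc(-c2nc3ncccn3c2NC2CCCCC2)cc1`, is not yet measured. It differs from compound 3 in one place: chloro in place of 3-carboxypropoxy on an aromatic carbon. Among the compounds with values here, no measured step covers this change. The expectation is a step toward a lower tolerated concentration, of modest size, possibly not beyond the scatter.

Compound 4 is estimated at 60000 nM, within 15000 nM to 100000 nM. The expected step is an at least 1.6-fold lower number from compound 3 to compound 4 (0.22 log units; that floor lies within the scatter).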

Compound 4, half-maximal cytotoxic concentration: > 100000 nM
Compound 4: only a limit was reported (the forecaster's own chance of this, stated with the estimate: 45%); middle value at least 1.6-fold (0.22 log units) from the limit.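

Compound 3 and compound 4 both give only limits, so no step can be read between them: the limit of > 100000 nM in this assay, at which 3 of the 4 values shown sit.

The compounds shown leave open whether chloro in place of 3-carboxypropoxy shifts the tolerated concentration at all.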